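The source may hold more compounds than are shown below. What is called first, only, known or untested is meant among the compounds shown, and "the series" means these compounds.

In an ADME assay on MT4 cells (Homo sapiens) for cytotoxicity, read by spectrophotometry, with a stated time of 5 days (a lower number here means that less compound is tolerated, a higher number that more compound is tolerated), the measured compounds are:
Compound 1, `CN(C)CN1C(=O)/C(=N\NC(=S)NO)c2cc(F)ccc21`: 599000 nM
Compound 2, `CONC(=S)N/N=C1\C(=O)N(CN2CCN(c3c(F)cc4c(=O)c(C(=O)O)cn(C5CC5)c4c3OC)CC2C)c2ccc(Cl)cc21`: 164000 nM

Of these two, compound 1 stands highest; the number for compound 2 lies lower, beyond the scatter. Compound 3, `Cc1ccc2c(c1)/C(=N/NC(=S)NO)C(=O)N2CN(C)C`, is built on the same core as compound 1 and differs from it in one place: methyl in place of fluoro on an aromatic carbon. Within the data shown here, no measured pair of this kind is available, so the size of the step in this assay has to be guessed; a change of methyl for fluoro at this place is expected to give a step no larger than the scatter, in either direction. For compound 3 the estimated value is 500000 nM, with a range from 250000 nM to 1000000 nM, which means an expected step of a 1.2-fold lower number from compound 1 to compound 3 (0.08 log units; within the scatter).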

Compound 3, half-maximal cytotoxic concentration: 651000 nM
Estimate against measurement, compound 3: 1.3-fold (0.11 log units) below; low and high end bracket the measured number.
By their numbers in this assay, from the lowest: compound 2; then compounds 1 and 3 (each within the scatter of the next).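

In this assay, among these compounds, the first measured exchange at this aromatic carbon, methyl in place of fluoro, gives a 1.1-fold higher number from compound 1 to compound 3 (0.04 log units; within the scatter). At this place on the shared core, the assay therefore does not separate the two groups, and the high tolerated concentration of compound 1 is retained in compound 3. Nothing available gives a reason for this result. The compounds shown leave open whether an amine, a methoxy group or a carboxylic acid on this carbon would fit the same picture, and whether hydrogen there would do so too.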